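Dichlorophenyl amide swap on the pyrazole series

The source may hold more compounds than are shown below. What is called first, only, known or untested is meant among the compounds shown, and "the series" means these compounds.

Measured so far:
compound 1 `COc1cc(-c2nn(-c3ccc(NC(=O)c4cc(Cl)cc(Cl)c4)cc3)cc2-c2ccncc2)ccc1Cl` gives 3090 nM in a functional assay on LOX IMVI cells (Homo sapiens) for antiproliferative activity, read by sulforhodamine B assay, with a stated time of 48 h; a higher number here means a weaker inhibitor, a lower number a stronger inhibitor;
compound 2 `O=C(Nc1ccc(-n2cc(-c3ccncc3)c(-c3ccc(Cl)c(O)c3)n2)cc1)Nc1ccc(Cl)c(C(F)(F)F)c1` gives 1440 nM;
compound 3 `O=C(Nc1ccc(-n2cc(-c3ccncc3)c(-c3ccc(Cl)c(O)c3)n2)cc1)c1ccc(Cl)c(Cl)c1` gives 1450 nM.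

Compound 3 holds the second highest number of the three; compound 2 sits within the scatter of it, and compound 1 lies beyond the scatter with the higher number. Compound 4 `O=C(Nc1ccc(-n2cc(-c3ccncc3)c(-c3ccc(Cl)c(O)c3)n2)cc1)c1cc(Cl)cc(Cl)c1` differs from compound 3 only by 3,5-dichlorophenyl in place of 3,4-dichlorophenyl on a carbonyl carbon. Within the data shown here, no measured step matches this swap. Among the measured compounds shown here, the one step on the carbonyl substituent, a 1.0-fold higher number from compound 2 to compound 3 (0.00 log units; within the scatter), changed nothing beyond the scatter. Compound 1 carries the 3,5-dichlorophenyl group but also differs elsewhere, so its value is only weak guidance. A small step is expected, a 1.2-fold higher number from compound 3 to compound 4 (0.09 log units; within the scatter). Compound 4 is estimated at 1800 nM, between 900 nM and 3600 nM.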

Compound 4, half-maximal inhibitory concentration: 1190 nM
For compound 4 the middle estimate is 1.5-fold (0.18 log units) above the measured one, and the stated range covers the measured number.
By their numbers in this assay, from the lowest: compounds 4, 2 and 3 (each within the scatter of the next); then compound 1.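

Changing 3,4-dichlorophenyl to 3,5-dichlorophenyl on the carbonyl carbon gives a 1.2-fold lower number from compound 3 to compound 4 (0.09 log units; within the scatter), and replacing the (4-chloro-3-(trifluoromethyl)phenyl)amino group with 3,5-dichlorophenyl gives a 1.2-fold lower number from compound 2 to compound 4 (0.08 log units; within the scatter), so neither swap separates these groups at this position. Among these compounds, with 3,5-dichlorophenyl held constant, hydrogen in place of methyl on the oxygen gives a 2.6-fold lower number from compound 1 to compound 4 (0.41 log units; beyond the scatter), the only step here beyond the scatter. No available evidence bears on these results.

Still open, as far as these compounds go, is whether an amine or a carboxylic acid in place of a chlorine would move the number beyond the scatter. From the compounds shown here alone, whether the hydrogen-for-methyl step holds with other groups on the carbonyl carbon also remains open.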